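The source may report more compounds than this note shows. Statements on the series, on what has been measured and on what is new or still open speak of the compounds shown alone.

The measured compounds:
Compound 1, `CC1=CC[C@H](C(=O)N(c2cc(C#CC(C)(C)C)sc2C(=O)O)[C@H]2CC[C@](O)(CO[C@H]3CCOC3)CC2)CC1`, in an ADME assay on the whole organism (strain Sprague-Dawley) with Rattus norvegicus as the target, at a dose of 0.5 mg/kg by the intravenous route (a lower number here means that the compound disappears faster, a higher number that the compound lasts longer), compound 1 gives 2.7 h.
Compound 2, `CC(C)(C)C#Cc1cc(N(C(=O)[C@H]2CC[C@H](C)CC2)[C@H]2CC[C@H](OC3CCOC3)CC2)c(C(=O)O)s1`, gives 3.5 h.
Compound 3, `CC(C)(C)C#Cc1cc(N(C(=O)[C@H]2CC[C@H](C)CC2)[C@H]2CC[C@](O)(CO[C@H]3CCOC3)CC2)c(C(=O)O)s1`, gives 3.8 h.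

Compound 2 stands second highest of the three numbers, within the scatter of both compound 3 and compound 1, so the three compounds cannot be told apart on this read-out. Compound 4, `CC(C)(C)C#Cc1cc(N(C(=O)[C@H]2CC[C@H](C)CC2)[C@H]2CC[C@H](Oc3ccncn3)CC2)c(C(=O)O)s1`, differs from compound 2 by pyrimidin-4-yl in place of oxolan-3-yl on an oxygen on a saturated carbon. Going by the values given here, the only measured step, a 1.4-fold higher number from compound 1 to compound 3 (0.15 log units; within the scatter), alters a different part of the molecule and does not bear on this exchange. Among the compounds with values here, no measured pair shows the effect of pyrimidin-4-yl in place of oxolan-3-yl on the mean residence time, so the expected step is a 1.2-fold lower number from compound 2 to compound 4 (0.07 log units; within the scatter), nothing beyond the scatter. Compound 4 is therefore estimated at 3 h, with a range from 1.4 h to 6.5 h.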

Compound 4, mean residence time: 7.1 h
The estimate for compound 4 lay 2.4-fold (0.37 log units) below the measured number; the whole stated range lies below it.
By their numbers in this assay, from the lowest: compounds 1, 2, 3 and 4 (each within the scatter of the next, the first and the last beyond it).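

In this assay, going by these compounds alone, a 2.0-fold higher number from compound 2 to compound 4 (0.31 log units; beyond the scatter), the first step in this set to clear the scatter, and a modest one. Within the data shown here, it shows that the group on this oxygen can shift the mean residence time, which the earlier compounds, all within the scatter of one another, could not show. Nothing at hand explains the step. Still open, as far as these compounds go, is whether this shift is specific to pyrimidin-4-yl or extends to other aromatic rings. A phenyl or a pyridin-4-yl group on the same oxygen would help to separate the two.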